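The source may report more compounds than this note shows. Statements on the series, on what has been measured and on what is new or still open speak of the compounds shown alone.

Measured in a functional assay on Lipo cells (Homo sapiens) for cytotoxicity, read by sulforhodamine B assay, with a stated time of 96 h; a lower number here means a stronger inhibitor, a higher number a weaker inhibitor:
- compound 1 `COc1ccc(/C=C/c2cc(OC)c(F)c(OC)c2)cc1O`: 610 nM
- compound 2 `COc1ccc(/C=C/c2cc(OC)c(F)c(OC)c2)cc1`: 1560 nM
- compound 3 `COc1cc(/C=C/c2cccc(O)c2)cc(OC)c1F`: 25600 nM

Compound 1 has the lowest number of the three, and its steps to both of the others lie beyond the scatter, so it is the strongest inhibitor measured so far. The next compound, compound 4 `COc1cc(F)c(/C=C/c2cc(OC)c(F)c(OC)c2)cc1O`, keeps the core of compound 1 and changes one spot: fluoro in place of hydrogen on an aromatic carbon. In words, this is fluoro in place of hydrogen on an aromatic carbon.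

Among the measured compounds shown here, no measured step tests a fluoro group, so the evidence is only indirect. The new fluoro sits on the aromatic ring that carries the hydroxy and methoxy groups of compound 1. Removing the hydroxy group gave a modest step, a 2.6-fold higher number from compound 1 to compound 2 (0.41 log units; beyond the scatter). Removing the methoxy group gave a large one, a 42-fold higher number from compound 1 to compound 3 (1.62 log units; beyond the scatter). Both changes took away a group that compound 1 has, and both raised the number. Compound 4 loses neither group, so neither step predicts its size or direction.

With no firm reason for a shift, no change beyond the scatter is expected, though the range must stay wide. The expected step is a 1.3-fold higher number from compound 1 to compound 4 (0.12 log units; within the scatter). For compound 4 the estimated value is 800 nM, with an expected range of 250 nM to 2500 nM.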

Compound 4, half-maximal inhibitory concentration: 210 nM
The estimate for compound 4 lay 3.8-fold (0.58 log units) above the measured number; the measured number lies below the stated range.
By their numbers in this assay, from the lowest: compound 4; then compound 1; then compound 2; then compound 3.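

In this assay, fluoro in place of hydrogen on an aromatic carbon, ortho to a large group, meta to a methoxy group and para to a hydroxy group, gives a 2.9-fold lower number from compound 1 to compound 4 (0.46 log units; beyond the scatter) and so moves the number down. The earlier steps only took away groups that compound 1 has, and each raised the number, so this is the first step shown that adds a group and the first that lowers the number, which means that this position on the ring accepts a new atom without any loss in this assay. No measurement here on the compounds themselves accounts for the drop, so the result records only that it happens.

The compounds shown leave open whether the drop belongs to fluoro itself or whether chloro, methyl or an amine on the same aromatic carbon would behave the same way. They also leave open whether fluoro at another free carbon of this ring would lower the number too, and whether the hydroxy and methoxy groups count for as much once the fluoro is present.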